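A few compounds are considered here, and "the series" means these few. Any claim that something is new, unique, unknown or untested is made for them only; others in the source may bear on it.

Compound 3, `Clc1cc(C2=NNC(c3ccc(N4CCCCC4)cc3)C2)c(Cl)s1`, was examined in an ADME assay on PBMC cells (Homo sapiens) for cytotoxicity, with a stated time of 5 days (on this read-out higher numbers stand for weaker inhibition and lower numbers for stronger inhibition), where compound 3 gave 59000 nM. Among the compounds for which this assay returned a number, compound 3 holds the lowest one; its nearest neighbour is compound 2, `Cc1cc(C2=NNC(c3ccc(N4CCCCC4)cc3)C2)c(C)s1`, for which compound 2 gave 77500 nM, and the step of a 1.3-fold lower number from compound 2 to compound 3 (0.12 log units; within the scatter) lies within the scatter. Compound 1, `c1cc(C2=NNC(c3ccc(N4CCCCC4)cc3)C2)cs1`, yielded only a limit in this assay, namely > 100000 nM. The steps of an at least 1.2-fold lower number from compound 1 to compound 2 (0.11 log units; that floor lies within the scatter) and an at least 1.6-fold lower number from compound 1 to compound 3 (0.22 log units; that floor lies within the scatter) therefore rest on the limit of > 100000 nM in this assay, at which 1 of the 3 values shown sits, and have only a floor, and that floor lies within the scatter.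

The compound still to be measured is compound 4, `Brc1ccc(C2=NNC(c3ccc(N4CCCCC4)cc3)C2)s1`. It differs from compound 3 by 5-bromothiophen-2-yl in place of 2,5-dichlorothiophen-3-yl on a carbon with a double bond to nitrogen. Going by the values given here, none of the measured steps exchanges the thiophene for one carrying a single bromine or moves the point at which it is attached; the three measured steps only vary what sits on a thiophen-3-yl, and all three stayed within the scatter. On that basis no step beyond the scatter is expected from compound 3 to compound 4 in this assay, so the expected step of a 1.0-fold higher number from compound 3 to compound 4 (0.01 log units; within the scatter) is small. Compound 4 is accordingly estimated at 60000 nM, with a range from 25000 nM to 150000 nM.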

Compound 4, half-maximal inhibitory concentration: 80000 nM
Compound 4: middle estimate off by 1.3-fold (0.12 log units), on the low side; measured number inside the range.
By their numbers in this assay, from the lowest: compounds 3, 2 and 4 (each within the scatter of the next). At a limit, above all of these: compound 1.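

In this assay, the change at this place on a carbon with a double bond to nitrogen now alters both the point of attachment of the thiophene and what it carries, and the result still stays inside the scatter: 5-bromothiophen-2-yl in place of 2,5-dichlorothiophen-3-yl gives a 1.4-fold higher number from compound 3 to compound 4 (0.13 log units; within the scatter), and in place of 2,5-dimethylthiophen-3-yl it gives a 1.0-fold higher number from compound 2 to compound 4 (0.01 log units; within the scatter). The earlier compounds shown here varied only what sits on a thiophen-3-yl, so compound 4 extends the same picture to a thiophen-2-yl with a single bromine, with no step that can be told from the scatter among compounds 2, 3 and 4. Against compound 1 there is only a floor, an at least 1.2-fold lower number from compound 1 to compound 4 (0.09 log units; that floor lies within the scatter), and it rests on a limit: the limit of > 100000 nM in this assay, at which 1 of the 4 values shown sits.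

The compounds shown leave open whether a group other than a thiophene at this place, such as a phenyl or a pyridine, would give a step beyond the scatter. They also leave open what a thiophen-2-yl without bromine, or one carrying an amine or a carboxylic acid, would give in this assay.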